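Aryl exchange on the shared core and compound 4

The compounds below may be only part of what the source reports. "The series", "measured", "known", "first", "only" and "open" are said of these compounds alone.

Compound 2 `COc1ccc(C)cc1-c1c(C)nn(-c2nc(-c3ccc(Cl)c(Cl)c3)c(SC(C)C)s2)c1C(=O)O` gives 9500 nM in a functional assay on BJAB cells (Homo sapiens) for antiproliferative activity, with a stated time of 4 days (on this read-out lower numbers stand for an effect already at smaller amounts and higher numbers for an effect only at larger amounts of compound), and stands highest of the three numbers in hand. Compound 1 `COc1ccc(-c2c(C)nn(-c3nc(-c4ccc(Cl)c(Cl)c4)c(SC(C)C)s3)c2C(=O)O)cc1` gives 2100 nM in this assay, and compound 3 `Cc1cc(C#N)cc(-c2c(C)nn(-c3nc(-c4ccc(Cl)c(Cl)c4)c(SC(C)C)s3)c2C(=O)O)c1` gives 4800 nM in this assay. The measured steps are a 4.5-fold higher number from compound 1 to compound 2 (0.66 log units; beyond the scatter), a 2.3-fold higher number from compound 1 to compound 3 (0.36 log units; beyond the scatter) and a 2.0-fold lower number from compound 2 to compound 3 (0.30 log units; within the scatter); exchanging the aryl group on the aromatic carbon has so far shifted the read-out only modestly. Compound 4 `Cc1nn(-c2nc(-c3ccc(Cl)c(Cl)c3)c(SC(C)C)s2)c(C(=O)O)c1-c1ccccc1C(F)(F)F` carries the change (2-(trifluoromethyl)phenyl in place of 2-methoxy-5-methylphenyl on an aromatic carbon). Among the compounds with values here, none of the measured steps brings in a trifluoromethyl group, so the size of the earlier aryl swaps is the only guide. Because compound 2 sits at 9500 nM while compound 1 sits at 2100 nM, the whole series spans a modest range, and compound 4 is expected to land inside it, with a small step in either direction possible. For compound 4 the estimate in this assay is 6000 nM, with a range from 2000 nM to 18000 nM. This corresponds to an expected step of a 1.6-fold lower number from compound 2 to compound 4 (0.20 log units; within the scatter).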

Compound 4, half-maximal effective concentration: 5200 nM
Estimate against measurement, compound 4: 1.2-fold (0.06 log units) above; the measured number falls inside the stated range.
By their numbers in this assay, from the lowest: compound 1; then compounds 3, 4 and 2 (each within the scatter of the next).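

In this assay the aromatic carbon of the five-membered ring also takes a fluorine-bearing aryl group: 2-(trifluoromethyl)phenyl, with no hydrogen-bond acceptor, in place of 2-methoxy-5-methylphenyl gives a 1.8-fold lower number from compound 2 to compound 4 (0.26 log units; within the scatter). Set against 3-cyano-5-methylphenyl, the same group gives a 1.1-fold higher number from compound 3 to compound 4 (0.03 log units; within the scatter), so three differently substituted aryl groups in compounds 2, 3 and 4 cannot be told apart on this read-out. The 4-methoxyphenyl group of compound 1 remains the one that stands apart, with a 2.5-fold higher number from compound 1 to compound 4 (0.39 log units; beyond the scatter), and only compound 1 has steps to all the others printed as beyond the scatter.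

On these data alone, whether an amine or a hydroxyl group on this aryl ring, or a phenyl with no substituent at all, would stay within this range remains open. Nothing at hand bears on the cause of these steps.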